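Pentyloxy for cyclohexylamino under a cytotoxicity limit

The compounds below may be only part of what the source reports. "The series", "measured", "known", "first", "only" and "open" are said of these compounds alone.

- compound 1 `CNc1nc(N)nc2c1ncn2/C=C1/CC1(CO)CO`: > 24000 nM
- compound 2 `Nc1nc(NC2CCCCC2)c2ncn(/C=C3/CC3(CO)CO)c2n1`: > 24000 nM

Both entries are limits of an ADME assay on Akata cells (Homo sapiens) for cytotoxicity, with a stated time of 7 days (a lower number here means that less compound is tolerated, a higher number that more compound is tolerated), not numbers. Compound 2 therefore has no exact place: it stands at the limit of > 24000 nM in this assay, at which 2 of the 2 values shown sit. Compound 3 `CCCCCOc1nc(N)nc2c1ncn2/C=C1/CC1(CO)CO` differs from compound 2 by this change: pentyloxy in place of cyclohexylamino on an aromatic carbon. For the measured compounds named here, the only measured step, a step that the two limits leave unreadable from compound 1 to compound 2, gives no size to carry over, so only a modest step, downward if any, is expected. The expected step is an at least 1.0-fold lower number from compound 2 to compound 3 (0.03 log units; that floor lies within the scatter). For compound 3 the estimated value is 22000 nM, with an expected range of 7000 nM to 40000 nM.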

Compound 3, half-maximal cytotoxic concentration: > 20000 nM
Compound 3: no number, only a limit; the forecaster's own chance of this, stated with the estimate: 60%; the middle value lies beyond the limit too.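

The steps among compound 1, compound 2 and compound 3 cannot be read: in this assay each gives only a limit, not a number. The compounds shown leave open where each true cytotoxic concentration lies, and whether these group changes shift it at all.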